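Methoxy in place of trifluoromethyl: compound 3 to compound 4

The source may hold more compounds than are shown below. What is called first, only, known or untested is meant among the compounds shown, and "the series" means these compounds.

In a physicochemical assay for solubility, using the shake flask method, in simulated intestinal fluid, measured as kinetic solubility, with a stated time of 2 h, at 25 degrees C, at pH 6.5 (a lower number here means a less soluble compound, a higher number a more soluble compound), compound 3 `Cc1noc(-c2nc(C)c3c(c2N)C(=O)N(Cc2ccccc2C(F)(F)F)C3=O)n1` gives < 5000 nM, which is a limit and not a number. Compound 1 `COc1ccc(CN2C(=O)c3c(C)nc(-c4nc(C)no4)c(N)c3C2=O)cc1` gives < 5000 nM, also a limit. Compound 2 `Cc1noc(-c2nc(C)c3c(c2N)C(=O)N(Cc2cccc(C(F)(F)F)c2)C3=O)n1` gives < 5000 nM, again a limit. The whole series therefore stands at the limit of < 5000 nM in this assay, at which 3 of the 3 values shown sit.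

Compound 4 `COc1ccccc1CN1C(=O)c2c(C)nc(-c3nc(C)no3)c(N)c2C1=O` carries methoxy in place of trifluoromethyl on an aromatic carbon, ortho to a large group (methoxy in place of trifluoromethyl on an aromatic carbon). The same difference, cut one bond further out, reads 2-(trifluoromethyl)phenyl to 2-methoxyphenyl.

Two measured comparisons bear on this change: a step that the two limits leave unreadable from compound 1 to compound 3 and a step that the two limits leave unreadable from compound 2 to compound 3. Neither has a size that can be carried over. For the measured compounds named here, compound 1 is the only measured compound with a methoxy group, as 4-methoxyphenyl, and a step that the two limits leave unreadable from compound 1 to compound 3 gives no direction.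

The expected step in this assay is a step that the limit leaves unreadable from compound 3 to compound 4, with no direction expected beyond the scatter. Another report as a limit is the likeliest outcome. For compound 4 the estimate is 3000 nM, with an expected range of 1000 nM to 7000 nM.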

Compound 4, solubility: < 5000 nM
Compound 4 was reported as a limit; the forecaster's own chance of this, stated with the estimate: 85%; the middle value is on the limit's open side.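

In this assay compound 4 gives < 5000 nM, which is a limit and not a number. No step can be read between compound 4 and compound 1, compound 2 or compound 3. The compounds shown leave open the actual solubility of each compound and whether any of these changes moves it: the limit of < 5000 nM in this assay, at which 4 of the 4 values shown sit.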